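The compounds below may be only part of what the source reports. "The series", "measured", "known", "first", "only" and "open" are said of these compounds alone.

Measured compounds in a functional assay on CCRF-CEM cells (Homo sapiens) for cytotoxicity, in the presence of a further agent that is not named here; on this read-out higher numbers stand for weaker inhibition and lower numbers for stronger inhibition:

compound 1 `COC(=O)c1ccc(CN(CCCc2c(N)nc(N)nc2O)c2cc(F)ccc2[N+](=O)[O-])cc1`: 30000 nM
compound 2 `Nc1nc(N)c(CCCN(Cc2ccc(NC(CCC(=O)O)C(=O)O)cc2)c2cc(F)ccc2[N+](=O)[O-])c(O)n1`: a limit of the assay, > 100000 nM
compound 3 `Nc1nc(N)c(CCCNc2cc(F)ccc2[N+](=O)[O-])c(O)n1`: a limit of the assay, > 100000 nM

Going by the values given here, compound 1 stands as the only compound with a number in this assay; the other two sit at the limit of the assay, (the limit of > 100000 nM in this assay, at which 2 of the 3 values shown sit). Both measured steps leave from compound 1 and alter the benzyl side of the molecule: an at least 3.3-fold higher number from compound 1 to compound 2 (0.52 log units; beyond the scatter) and an at least 3.3-fold higher number from compound 1 to compound 3 (0.52 log units; beyond the scatter). Each is a loss that cannot be bounded from above, since the value it leads to is a limit.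

Compound 4 `COC(=O)c1ccc(CN(CCCc2c(N)nc(N)nc2O)c2ccc([N+](=O)[O-])c(F)c2F)cc1` is not yet measured in this assay. It differs from compound 1 at the other side of the amine nitrogen: 2,3-difluoro-4-nitrophenyl in place of 5-fluoro-2-nitrophenyl on an amine nitrogen. Among the compounds with values here, neither measured step touches the aryl group on that nitrogen, so no measured step bears on this change. Within the data shown here, the only anchor is the value of compound 1, 30000 nM, which is itself weak.

Compound 4 is therefore estimated to give about 40000 nM in this assay, within a range from 10000 nM to 150000 nM. This expectation amounts to a 1.3-fold higher number from compound 1 to compound 4 (0.12 log units; within the scatter), with a real chance that only a limit is reported.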

Compound 4, half-maximal inhibitory concentration: 45000 nM
Compound 4: middle estimate off by 1.1-fold (0.05 log units), on the low side; the measured number falls inside the stated range.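

Going by these compounds alone, the aryl group on the amine nitrogen, which the earlier steps left untouched, now has a reading in this assay: the change gives a 1.5-fold higher number from compound 1 to compound 4 (0.18 log units; within the scatter), so 2,3-difluoro-4-nitrophenyl and 5-fluoro-2-nitrophenyl cannot be told apart on this read-out. This single swap adds a fluorine and rearranges the groups on the ring, yet it stays within the scatter, whereas the two measured changes on the benzyl side of compound 1 were both beyond it. Compound 2 and compound 3 remain limits of the assay rather than numbers, and compound 4 does not join them: the limit of > 100000 nM in this assay, at which 2 of the 4 values shown sit.

This position rests on one pair of compounds, and both of its aryl groups carry nitro and fluorine, so the tolerance seen here cannot be extended to other groups. How an aryl group with an amine or a carboxylic acid in place of nitro would read remains open, as does the effect of a longer chain on the amine nitrogen, and neither question can be answered from the compounds shown.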